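Hydroxy on the outer ring of compound 3

This account rests on a few compounds, and the source may have more. Where it says the series, first, only, none or still open, it means among the compounds named here.

Compound 3 `Cc1ccccc1-c1cccc(CNc2ccc(OCC(=O)O)c(F)c2)c1` gives 4.8 nM in a functional assay on CHO cells for agonist activity at Free fatty acid receptor 1 (Homo sapiens), read by FLIPR and calcium flux (on this read-out higher numbers stand for an effect only at larger amounts of compound and lower numbers for an effect already at smaller amounts), and stands lowest among the three measured compounds. Compound 1 `CCOc1cc(C)c(-c2cccc(CNc3ccc(OCC(=O)O)c(F)c3)c2)c(C)c1` gives 24.2 nM and compound 2 `COCCOc1cc(C)c(-c2cccc(CNc3ccc(OCC(=O)O)c(F)c3)c2)c(C)c1` gives 51.6 nM; both carry an alkoxy group on the outer ring para to the large group, where compound 3 carries hydrogen, but they also differ from compound 3 in a second methyl, so only their values can be compared, not a single step.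

Compound 4 `Cc1cc(O)ccc1-c1cccc(CNc2ccc(OCC(=O)O)c(F)c2)c1` differs from compound 3 by hydroxy in place of hydrogen on an aromatic carbon. For the measured compounds named here, the one measured step that touches the same region, a 2.1-fold higher number from compound 1 to compound 2 (0.33 log units; beyond the scatter), shows a modest rise in the number when the oxygen-bearing side chain is extended. Going by the values given here, no measured pair isolates hydrogen against hydroxy on this ring, so the expectation rests on the direction of that step and on the higher numbers of compound 1 and compound 2. A modest rise, a 1.9-fold higher number from compound 3 to compound 4 (0.27 log units; within the scatter), is expected for compound 4. Compound 4 is estimated at 9 nM, within 3 nM to 30 nM.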

Compound 4, half-maximal effective concentration: 69.6 nM
Compound 4: middle estimate off by 7.7-fold (0.89 log units), on the low side; the measured number lies above the stated range.
By their numbers in this assay, from the lowest: compound 3; then compound 1; then compounds 2 and 4 (each within the scatter of the next).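

With 2-methylphenyl changed to 4-hydroxy-2-methylphenyl, this assay gives a 15-fold higher number from compound 3 to compound 4 (1.16 log units; beyond the scatter), the first step shown that isolates a single change on the aromatic carbon para to a large group. The earlier compounds shown here carry oxygen on this carbon only alongside a second methyl group, so they could not show what this change does alone; this pair shows that hydroxy in place of hydrogen is enough to produce a large step. Nothing available explains the size of this step.

The compounds shown leave open whether methoxy or an amine on this carbon would give a step of similar size to that of hydroxy. They also leave open whether hydroxy would produce the same step on the outer ring with a second methyl group present.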